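Swapping a Pyridyl Tail for an Imidazolylethyl Tail

This account rests on a few compounds, and the source may have more. Where it says the series, first, only, none or still open, it means among the compounds named here.

Compound 1 `O=C(NC[C@H](NS(=O)(=O)c1ccccc1)C(=O)O)c1cc2cc(OCC3CCNCC3)ccc2n1Cc1ccccc1`: 150 nM
Compound 2 `O=C(NC[C@H](NS(=O)(=O)c1ccccc1)C(=O)O)c1cc2cc(OCc3ccncc3)ccc2[nH]1`: 280 nM

Of the compounds shown here, two sharing one core have been tested in a functional assay for inhibition, with Homo sapiens as the target; on this read-out lower numbers stand for stronger inhibition and higher numbers for weaker inhibition. Compound 1 gives 150 nM. Compound 2 gives 280 nM. On the numbers shown, compound 2 stands at the higher reading of the pair, but its gap to compound 1 falls inside the scatter of repeated measurements, so neither compound can be called more or less potent than the other.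

The next compound is compound 3 `O=C(NC[C@H](NS(=O)(=O)c1ccccc1)C(=O)O)c1cc2cc(OCCCc3c[nH]cn3)ccc2[nH]1`. It differs from compound 2 in one place: 2-(1H-imidazol-4-yl)ethyl in place of pyridin-4-yl on a saturated chain carbon bound to an oxygen on an aromatic ring. Among the measured compounds shown here, no pair of measured compounds shows this change, so there is no measured step to lean on. For the measured compounds named here, the only guide is that the two measured compounds, with different groups at this same position, sit within the scatter of each other.

Compound 3 is therefore estimated to give about 250 nM, with a range from 90 nM to 700 nM. That estimate means an expected step of a 1.1-fold lower number from compound 2 to compound 3 (0.05 log units; within the scatter), which is expected to stay within the scatter rather than mark a real gain or loss.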

Compound 3, half-maximal inhibitory concentration: 100 nM
Compound 3: the middle estimate sits 2.5-fold (0.40 log units) above what was measured; low and high end bracket the measured number.
By their numbers in this assay, from the lowest: compounds 3, 1 and 2 (each within the scatter of the next, the first and the last beyond it).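

In this assay, the change from pyridin-4-yl to 2-(1H-imidazol-4-yl)ethyl gives a 2.8-fold lower number from compound 2 to compound 3 (0.45 log units; beyond the scatter), a modest step but the first one here that can be read as a real difference. Compounds 1 and 2 differ in more than one place, so they could not show this; this single change shows that the group on the saturated chain carbon bound to an oxygen on an aromatic ring can alter the read-out on its own. The data offer no measured explanation for the step, so its cause remains unknown.

This one swap also changes several things together: a six-membered aromatic ring with 1 hetero atom gives way to a five-membered aromatic ring with 2 hetero atoms, a hydrogen-bond donor enters, and an ethyl chain now carries the ring. The compounds shown therefore leave open which of these matters, and whether a 2-(pyridin-4-yl)ethyl group, a 1H-imidazol-4-yl group without the ethyl chain, or a simple amine at the end of the same chain would give a similar number.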